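The source may hold more compounds than are shown below. What is called first, only, known or untested is meant among the compounds shown, and "the series" means these compounds.

Compounds measured so far:
- Compound 1 `Cc1c(Nc2nc(N)c3c(C#N)c(N4CCC[C@H]4C)n(C)c3n2)cnn1[C@H]1CCOC1`: 23.3 mL/min/kg
- Compound 2 `Cc1c(Nc2nc(N)c3c(C#N)c(N4CCC[C@H]4C)n(C)c3n2)cnn1CC1(O)COC1`: 35 mL/min/kg

Going by the values given here, in an ADME assay on microsomes from liver (Homo sapiens) for pharmacokinetics (on this read-out higher numbers stand for fast clearance and lower numbers for slow clearance), compound 2 gives 35 mL/min/kg and compound 1, the only other compound measured, gives 23.3 mL/min/kg. These two values lie within the scatter of each other, so compound 2 stands level with compound 1. Compound 3 `Cc1c(Nc2nc(N)c3c(C#N)c(N4CCC[C@H]4C)n(C)c3n2)cnn1C1COC1` shares the core of compound 2 and differs from it on an aromatic nitrogen of the five-membered aromatic ring, where oxetan-3-yl takes the place of (3-hydroxyoxetan-3-yl)methyl: oxetan-3-yl in place of (3-hydroxyoxetan-3-yl)methyl on an aromatic nitrogen. Among the compounds with values here, only one measured change bears on this, made on the same aromatic nitrogen: a 1.5-fold higher number from compound 1 to compound 2 (0.18 log units; within the scatter). On that evidence, no step beyond the scatter is expected in this assay, in either direction. The expected step is a 1.3-fold lower number from compound 2 to compound 3 (0.11 log units; within the scatter). For compound 3 the estimate is 27 mL/min/kg, with an expected range from 14 mL/min/kg to 50 mL/min/kg.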

Compound 3, clearance: 14.3 mL/min/kg
The estimate for compound 3 lay 1.9-fold (0.28 log units) above the measured number; the measured number falls inside the stated range.
By their numbers in this assay, from the lowest: compounds 3, 1 and 2 (each within the scatter of the next, the first and the last beyond it).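

In this assay, this aromatic nitrogen now shows a change beyond the scatter, which the earlier pair did not show: oxetan-3-yl in place of (3-hydroxyoxetan-3-yl)methyl gives a clear step (a 2.4-fold lower number from compound 2 to compound 3 (0.39 log units; beyond the scatter)). Oxetan-3-yl in place of oxolan-3-yl stays within the scatter (a 1.6-fold lower number from compound 1 to compound 3 (0.21 log units; within the scatter)), so only the pair of compound 2 and compound 3 is separated at this position. Nothing measured here accounts for the step between them.

The step exchanges the whole group, so the compounds shown cannot tell whether the hydroxy group or the methylene link between the rings matters on its own. As far as these compounds go, it also remains open where an amine such as azetidin-3-yl, or a longer chain such as 2-methoxyethyl, would stand on this nitrogen.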